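The compounds below may be only part of what the source reports. "The series", "measured", "known", "first", "only" and "open" are said of these compounds alone.

Notes on the series, read in a physicochemical assay for lipophilicity, using the shake flask method, in phosphate buffer, measured as octanol-water partition, with a stated time of 30 min, at pH 7.4 (on this read-out lower numbers stand for lower lipophilicity and higher numbers for higher lipophilicity), throughout. Compound 1 (`Cn1nccc1-c1cnc(NCc2c(F)ccc3c2CCO3)c2cn[nH]c(=O)c12`) gives 2.6 and compound 2 (`Cc1ncccc1-c1cnc(NCc2c(F)ccc3c2CCO3)c2n[nH]c(=O)n12`) gives 2.5, two values within the scatter of each other. Compound 3 (`CN(c1ccccc1)c1cnc(NCc2c(F)ccc3c2CCO3)n2cnnc12`) stands highest of the three at 3.6 and lies beyond the scatter from both others. For the measured compounds named here, no pair measured so far differs in one place only, so no measured step guides the next change. Compound 4 (`O=C1CC2(CC2)CN1c1cnc(NCc2c(F)ccc3c2CCO3)n2cnnc12`) carries, on an aromatic carbon of the core it shares with compound 3, a new group in place of methyl(phenyl)amino (a group of 8 heavy atoms (6 carbon, 1 nitrogen, 1 oxygen; one three-membered non-aromatic ring of carbon only, one five-membered non-aromatic ring with 1 hetero atom) in place of a group of 8 heavy atoms (7 carbon, 1 nitrogen; one six-membered aromatic ring of carbon only), on an aromatic carbon). Compound 3 (3.6) sits at the top of the range seen so far, while compound 1 (2.6) and compound 2 (2.5) show that the series reaches clearly lower numbers, so a move down is the likelier direction. In this assay the estimated change is a fall beyond the scatter (a number 0.90 log units lower from compound 3 to compound 4 (beyond the scatter)). For compound 4 the expected value is 2.7 within a range from 2.2 to 3.2 as an estimate resting on three compounds only.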

Compound 4, distribution coefficient: 1.9
The estimate for compound 4 lay 0.80 log units above the measured number, outside the stated range (below it).
By their numbers in this assay, from the lowest: compound 4; then compounds 2 and 1 (each within the scatter of the next); then compound 3.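

In this assay, the aromatic carbon of the core shared by compound 3 and compound 4 proves sensitive to what it carries: with methyl(phenyl)amino leaving and the new group entering, the read-out shows a number 1.70 log units lower from compound 3 to compound 4 (beyond the scatter), a large step beyond the scatter. The step arises although heavy-atom count, hydrogen-bond donor and acceptor counts and net charge stay the same on both sides, so these counts do not account for it; what differs is the six-membered aromatic ring of carbon giving way to two non-aromatic rings and a double bond outside aromatic rings. No measurement on hand ties the step to any one of these differences.

For the compounds shown here, the single step leaves the share of each difference unresolved. Also open, going by these compounds, is how a smaller open-chain group at this carbon, such as dimethylamino, or a morpholine would read.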